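The source may hold more compounds than are shown below. What is called first, only, known or untested is meant among the compounds shown, and "the series" means these compounds.

In a functional assay on U-937 cells (Homo sapiens), read by cAMP accumulation (on this read-out lower numbers stand for an effect already at smaller amounts and higher numbers for an effect only at larger amounts of compound), compound 1 `CCc1nn(C2CCCC2)c2c1CCN(c1cccc(OC)c1)C2=O` gives 330 nM and compound 2 `CCc1nn(C2CCC2)c2c1CCN(c1cccc(OC)c1)C2=O` gives 520 nM, so compound 1 shares the low end of the numbers with compound 2: a 1.6-fold higher number from compound 1 to compound 2 (0.20 log units; within the scatter). Compound 3 `CCc1nn(C2CCS(=O)(=O)C2)c2c1CCN(c1cccc(OC)c1)C2=O` gives 5270 nM, far from both: a 16-fold higher number from compound 1 to compound 3 (1.20 log units; beyond the scatter) and a 10-fold higher number from compound 2 to compound 3 (1.01 log units; beyond the scatter). Compound 4 `CCc1nn(C2CCCC2)c2c1CCN(c1ccsc1)C2=O` keeps the cyclopentyl of compound 1 but changes another place: thiophen-3-yl in place of 3-methoxyphenyl on an amide-type nitrogen in a ring. All three measured steps concern the group on the aromatic nitrogen, so none of them measures this swap, and their size cannot simply be carried over. With no direct guide, only a modest shift in this assay is expected: a 1.8-fold higher number from compound 1 to compound 4 (0.26 log units; within the scatter). For compound 4 the estimated value is 600 nM, with an expected range from 150 nM to 2500 nM.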

Compound 4, half-maximal effective concentration: 36 nM
For compound 4 the middle estimate is 17-fold (1.22 log units) above the measured one; the whole stated range lies above it.
By their numbers in this assay, from the lowest: compound 4; then compounds 1 and 2 (each within the scatter of the next); then compound 3.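

In this assay, the amide-type nitrogen in a ring proves to be a sensitive position: thiophen-3-yl in place of 3-methoxyphenyl gives a 9.2-fold lower number from compound 1 to compound 4 (0.96 log units; beyond the scatter). This is the first step among these compounds to a lower number beyond the scatter, and the entering group has fewer heavy atoms than the one it replaces. Nothing available explains why this swap lowers the number.

The swap changes the ring and removes the methoxy group together, so a plain phenyl or a furan-3-yl group at this place would be needed to separate those changes. Going by these compounds, whether thiophen-3-yl acts similarly alongside the cyclobutyl of compound 2 also stays open.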